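The source may hold more compounds than are shown below. What is called first, only, known or untested is meant among the compounds shown, and "the series" means these compounds.

Compound 1 `O=C(Nc1cccc(O)c1)C1c2ccccc2CCN1C(=O)c1ccc(Cl)cc1` was tested in a functional assay on NUGC-3 cells (Homo sapiens) for inhibition, read by sulforhodamine B assay, with a stated time of 48 h; on this read-out lower numbers stand for stronger inhibition of growth and higher numbers for weaker inhibition of growth. In this assay compound 1 gives > 10000 nM, which is a limit of the assay rather than a number. Compound 2 `O=C(Nc1ccc(O)cc1)c1nccc2ccccc12` is a second member of the same series. In this assay compound 2 gives > 10000 nM, again only a limit. Both results sit at the limit of > 10000 nM in this assay, at which 2 of the 2 values shown sit, so the measured data do not separate the two compounds. Compound 3 `COc1ccc(NC(=O)C2c3ccccc3CCN2C(=O)c2ccc(Cl)cc2)cc1` has not yet been measured. It differs from compound 1 in one place: 4-methoxyphenyl in place of 3-hydroxyphenyl on an amide-type nitrogen. Among the compounds with values here, no pair of measured compounds differing in a single place is available to gauge this change, so the size of the step can only be estimated. Because compound 1 sits at the limit of > 10000 nM in this assay, at which 2 of the 2 values shown sit, the step expected from compound 1 to compound 3 is small, a step that the limit leaves unreadable from compound 1 to compound 3, and no clearer than the scatter. Compound 3 is expected to give about 15000 nM, within 4000 nM to 60000 nM, most likely again reported only as a limit.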

Compound 3, concentration for 50% growth inhibition: 3630 nM
Beside the measured number, compound 3's estimate is 4.1-fold (0.62 log units) above it; the whole stated range lies above it.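

In this assay, the group on the amide-type nitrogen proves able to change the result: 4-methoxyphenyl in place of 3-hydroxyphenyl gives an at least 2.7-fold lower number from compound 1 to compound 3 (0.44 log units; beyond the scatter). The two earlier compounds could not show this, as neither gave a number, whereas compound 3 gives a measured value that can be read on this core. Going by these compounds, the full size of the step stays unknown because compound 1 has only a limit: the limit of > 10000 nM in this assay, at which 2 of the 3 values shown sit.

This single change moves the oxygen-bearing group to a different ring position and also replaces hydroxy with methoxy, and the compounds shown do not separate these two parts of the change. On these data alone, it also remains open how 3-methoxyphenyl, or a group with an amine such as 4-aminophenyl, would behave at this position on the same core.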